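Compound 4: one more methoxy on compound 3

The compounds below may be only part of what the source reports. "The series", "measured", "known", "first", "only" and "open" are said of these compounds alone.

Measured in a functional assay on Gurav cells (Homo sapiens) for inhibition, read by sulforhodamine B assay; on this read-out lower numbers stand for stronger inhibition of growth and higher numbers for weaker inhibition of growth:
- compound 1 `COc1cc(-c2ccc(-c3ccc(-c4nc5cc(C)ccc5[nH]4)cc3)cc2)cc(OC)c1OC`: 170 nM
- compound 2 `COc1cc(-c2ccc(-c3ccc(-c4nc5ccccc5[nH]4)cc3)cc2)cc(OC)c1OC`: 7100 nM
- compound 3 `COc1ccc(-c2ccc(-c3ccc(-c4nc5c(O)cccc5[nH]4)cc3)cc2)cc1OC`: 1110 nM

Compound 3 at 1110 nM stands in the middle of these numbers: compound 2 at 7100 nM is higher and compound 1 at 170 nM is lower, both gaps beyond the scatter.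

Compound 4 `COc1cc(-c2ccc(-c3ccc(-c4nc5c(O)cccc5[nH]4)cc3)cc2)cc(OC)c1OC` differs from compound 3 by methoxy in place of hydrogen on an aromatic carbon, ortho to a methoxy group: methoxy in place of hydrogen on an aromatic carbon. For the measured compounds named here, no measured step covers this change. Going by the values given here, the only single-place step available is a 42-fold higher number from compound 1 to compound 2 (1.62 log units; beyond the scatter), a large move for a different change, hydrogen in place of methyl. It shows that one small substituent can move this assay well beyond the scatter, but it gives no direction for methoxy. Compound 4 keeps the hydroxy-bearing part of compound 3 and gains the methoxy pattern shared by compound 1 and compound 2, a pair that spans a wide range. A modest step towards a lower number is therefore expected, with wide uncertainty: a 2.2-fold lower number from compound 3 to compound 4 (0.35 log units; beyond the scatter). For compound 4 the estimated value is 500 nM, with an expected range of 100 nM to 2500 nM.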

Compound 4, concentration for 50% growth inhibition: 170 nM
Compound 4: middle estimate off by 2.9-fold (0.47 log units), on the high side; the range from low to high includes it.
By their numbers in this assay, from the lowest: compounds 1 and 4 (each within the scatter of the next); then compound 3; then compound 2.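

Methoxy in place of hydrogen on an aromatic carbon, ortho to a methoxy group, gives in this assay a 6.5-fold lower number from compound 3 to compound 4 (0.81 log units; beyond the scatter) and is the first reading of this change in the series, showing that this position responds to it with stronger inhibition of growth. With that methoxy pattern in place, the added hydroxy group gives a 42-fold lower number from compound 2 to compound 4 (1.62 log units; beyond the scatter) as a large step, and 4-hydroxy-1H-benzimidazol-2-yl in place of 5-methyl-1H-benzimidazol-2-yl gives no change at the digits printed from compound 1 to compound 4 (within the scatter) so that the two substituted groups cannot be told apart on this read-out. No supporting evidence accompanies these numbers to explain the steps.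

The compounds shown leave open whether the methoxy step carries over to compounds without the hydroxy group, and whether hydroxy and methyl would still read alike if both stood at the same place. They also leave open how this position would respond to an amine, a carboxylic acid or a longer chain such as ethoxy in place of the new methoxy.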